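This account rests on a few compounds, and the source may have more. Where it says the series, first, only, none or still open, it means among the compounds named here.

In a functional assay on MDA-MB-231 cells (Homo sapiens) for cytotoxicity, read by sulforhodamine B assay, with a stated time of 72 h (a lower number here means that less compound is needed, a higher number that more compound is needed for the effect), three compounds sharing one core have been tested, and none of them gives a number. Compound 1 `Cc1cccc(-c2cc3occ(C)c3c(=O)o2)c1` gives only a limit, > 83.3 uM. Compound 2 `Cc1coc2cc(-c3cccc(O)c3)oc(=O)c12` also gives only a limit, > 41.3 uM. Compound 3 `COc1cc(OC)cc(-c2cc3occ(C)c3c(=O)o2)c1` stands at a limit too, > 69.9 uM. Compound 4 `COc1cc(-c2cc3occ(C)c3c(=O)o2)cc(OC)c1OC` differs from compound 3 by one change, methoxy in place of hydrogen on an aromatic carbon, ortho to two methoxy groups and para to a large group. Among the compounds with values here, the one measured step, a step that the two limits leave unreadable from compound 1 to compound 2, has no readable size, so it offers no scale. The estimated step of an at least 1.1-fold lower number from compound 3 to compound 4 (0.06 log units; that floor lies within the scatter) is therefore small, with only a slight expected lean towards less compound being needed. For compound 4 the estimated value is 60 uM, with an expected range from 20 uM to 100 uM.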

Compound 4, concentration for half-maximal effect: > 31.6 uM
Compound 4: a limit, no number; the forecaster's own chance of this, stated with the estimate: 70%; the middle value lies beyond the limit too.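

Within the data shown here, compound 4 gives only a limit of > 31.6 uM and compound 3 also gives only a limit, so no step between them can be read. Going by these compounds, whether adding a methoxy group changes the cytotoxicity remains open.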